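Notes on removing the ring methyl from compound 2

The source may hold more compounds than are shown below. What is called first, only, known or untested is meant among the compounds shown, and "the series" means these compounds.

Measured in an assay on cells for inhibition of Amine oxidase [flavin-containing] A (Homo sapiens), read by fluorescence and Amplex Red, with a stated time of 15 min; on this read-out lower numbers stand for stronger inhibition and higher numbers for weaker inhibition:
compound 1 `Cc1cccc2cc(-c3ccc(Br)cc3)oc12` — 100000 nM
compound 2 `Cc1ccc2oc(-c3ccccc3Br)cc2c1` — 11000 nM
compound 3 `Cc1ccc2oc(-c3ccccc3)cc2c1` — a limit of the assay, > 100000 nM

Compound 2 stands lowest of the two numbers given in this assay. The nearest number is that of compound 1, which differs from compound 2 in two places and sits well above it. One of the three values shown is the limit of > 100000 nM in this assay, at which 1 of the 3 values shown sits.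

Compound 4 `Brc1ccccc1-c1cc2ccccc2o1` is to be measured in this assay; its change from compound 2 is hydrogen in place of methyl on an aromatic carbon. Among the measured compounds shown here, the only measured step concerns a different group: an at least 9.0-fold higher number from compound 2 to compound 3 (0.95 log units; beyond the scatter), where hydrogen replaced bromo on an aromatic carbon. That step was large. For the measured compounds named here, no measured step removes a methyl. Compound 1 is no clean guide to it, since it also moves the bromo. Without a direct precedent, the methyl removal is expected to cost less than the bromo removal did, most likely a small loss within or near the scatter. For compound 4 the expected value in this assay is 20000 nM, with a range of 5000 nM to 80000 nM. The expected step is a 1.8-fold higher number from compound 2 to compound 4 (0.26 log units; within the scatter).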

Compound 4, half-maximal inhibitory concentration: 8120 nM
Compound 4: the middle estimate sits 2.5-fold (0.39 log units) above what was measured, and the stated range covers the measured number.
By their numbers in this assay, from the lowest: compounds 4 and 2 (each within the scatter of the next); then compound 1.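

In this assay, among the compounds shown here, the first measured step at this position reads a 1.4-fold lower number from compound 2 to compound 4 (0.13 log units; within the scatter), so hydrogen in place of methyl on this aromatic carbon, meta to a fused ring and para to a fused ring, leaves the number within the scatter. The methyl therefore separates from the bromo in this short series, since the bromo step reads an at least 9.0-fold higher number from compound 2 to compound 3 (0.95 log units; beyond the scatter), which lies beyond the scatter, and compound 2 and compound 4 both keep the bromo while differing only at the methyl position. Compound 3 lacks the bromo and carries a limit of the assay rather than a number, so the bromo step has a lower bound but no fixed size: the limit of > 100000 nM in this assay, at which 1 of the 4 values shown sits.

The compounds shown leave open whether this position tolerates anything other than methyl and hydrogen, such as a methoxy, an amine or a carboxylic acid, as only those two substituents are compared here. Also open, as far as these compounds go, are whether the bromo step holds on the core without the methyl and whether a chloro or a nitrile could take the place of the bromo.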